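The source may report more compounds than this note shows. Statements on the series, on what has been measured and on what is new or still open speak of the compounds shown alone.

Measured so far:
- compound 1, `Cc1ccc(-c2c(S(=O)(=O)c3ccccc3)cnc3cc(C)nn23)cc1`: 23.2%
- compound 2, `O=S(=O)(c1ccccc1)c1cnc2cc(-c3ccc(Cl)cc3)nn2c1-c1ccc(Br)cc1`: 24.8%

Of the compounds shown here, two have been measured in a functional assay on the whole organism for inhibition, with Mus musculus as the target, with a stated time of 3 h, at a dose of 50 mg/kg by the oral route; a lower number here means less inhibition, a higher number more inhibition at the dose given (going by the name of the read-out). Compound 1 gives 23.2% and compound 2 gives 24.8%. Compound 2 has the higher of the two numbers, but the gap to compound 1 lies within the usual scatter, so the two cannot be told apart. Compound 3, `Cc1cc2ncc(S(=O)(=O)c3ccccc3)c(-c3ccc(Br)cc3)n2n1`, is not yet measured. Compared with compound 2 the change is methyl in place of 4-chlorophenyl on an aromatic carbon. Compound 1 carries a methyl at that same ring carbon and its result sits together with that of compound 2, so a step of much size in this assay is not expected, neither up nor down beyond the scatter. Compound 3 is therefore expected to give about 24%, likely between 12% and 38%, which means an expected step of a number 0.8 percentage points lower from compound 2 to compound 3 (within the scatter).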

Compound 3, a percentage reported as inhibition, in the whole organism at one dose (the size of the read-out at that dose, not a potency): 4.4%
Compound 3: the middle estimate sits 19.6 percentage points above what was measured, outside the stated range (below it).
By their numbers in this assay, from the lowest: compound 3; then compounds 1 and 2 (each within the scatter of the next).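

In this assay methyl in place of 4-chlorophenyl on an aromatic carbon of the five-membered aromatic ring gives a number 20.4 percentage points lower from compound 2 to compound 3 (beyond the scatter) and so shows that the group at this position matters when the rest of the molecule is held fixed. Bromo in place of methyl on an aromatic carbon gives a number 18.8 percentage points lower from compound 1 to compound 3 (beyond the scatter) as well, so a single change from either earlier compound leads to the low number of compound 3, something the close results of compounds 1 and 2, which differ in more than one place, could not reveal. Nothing measured here explains either step.

Still open, from the compounds shown here alone, is how other groups at this ring carbon, such as an amine or a longer chain, would fare against methyl and 4-chlorophenyl. Also open, going by these compounds, is whether the loss seen with methyl there would hold with a group other than bromo on the other aromatic ring.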